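Allyl-substituted core: dichlorophenyl variant of compound 1

The compounds below may be only part of what the source reports. "The series", "measured", "known", "first", "only" and "open" are said of these compounds alone.

Measured so far:
- compound 1, `C=CCn1c(=O)/c(=C\c2cc(F)ccc2C)[nH]c(=O)/c1=C\c1ccccc1OC`: 1000 nM
- compound 2, `C=CCn1c(=O)/c(=C\c2cc(OC)c(OC)c(OC)c2)[nH]c(=O)/c1=C\c1cccc(Br)c1`: "not active" (no number reported)
- compound 3, `COc1ccccc1/C=c1/[nH]c(=O)/c(=C\c2nc[nH]c2C(C)(C)C)[nH]c1=O`: 50 nM

In a functional assay on U-937 cells (Homo sapiens) for cytotoxicity, read by CCK-8 assay, with a stated time of 72 h (on this read-out lower numbers stand for stronger inhibition and higher numbers for weaker inhibition), compound 1 gives 1000 nM. Of the two compounds with a number, compound 1 stands highest; the nearer neighbour, compound 3, gives 50 nM in this assay, a clearly lower number, beyond the scatter. Compound 2 gives "not active" (no number reported) in this assay without a number. Among the compounds with values here, no two measured compounds differ in only one place, so no single step is available for comparison.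

The next compound, compound 4, `C=CCn1c(=O)/c(=C\c2cccc(Cl)c2Cl)[nH]c(=O)/c1=C\c1ccccc1OC`, is the untested partner of compound 1. The difference is 2,3-dichlorophenyl in place of 5-fluoro-2-methylphenyl on a double-bonded chain carbon bound to an aromatic carbon. The aryl group on the other side of the core and the allyl group stay as in compound 1.

Within the data shown here, nothing among the measured compounds isolates the effect of swapping one halogen-bearing aryl group for another on this side of the core, so no direction can be read from the data. The step from compound 1 to compound 4 is expected to be no change at the digits printed from compound 1 to compound 4 (within the scatter), that is, none beyond the scatter. In this assay compound 4 is expected to give about 1000 nM, estimated between 300 nM and 3500 nM.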

Compound 4, half-maximal inhibitory concentration: 500 nM
Compound 4: the middle estimate sits 2.0-fold (0.30 log units) above what was measured, and the stated range covers the measured number.
By their numbers in this assay, from the lowest: compound 3; then compounds 4 and 1 (each within the scatter of the next).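

In this assay, 2,3-dichlorophenyl in place of 5-fluoro-2-methylphenyl on a double-bonded chain carbon bound to an aromatic carbon gives a 2.0-fold lower number from compound 1 to compound 4 (0.30 log units; within the scatter) and so stays inside the usual spread of repeat measurements. Within the data shown here, this is the first comparison that changes one place only, and it shows that this position accepts either of these two halogen-bearing aryl groups with no step beyond the scatter, even though the fluorine and methyl are exchanged for two chlorines. No measured property on hand accounts for the two groups reading alike.

Going by these compounds, whether the position stays this tolerant for a phenyl carrying an amine or a carboxylic acid, or for an aryl group without halogen, remains open, as the two groups compared here are alike in carrying halogen on a phenyl. Also open, on these data alone, is what sets compound 3 at 50 nM in this assay, as it differs from compound 1 and compound 4 in more than one place, and the allyl group and the aryl group on the other side of the core have no single-place comparison of their own.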